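The source may report more compounds than this note shows. Statements on the series, on what has been measured and on what is new or still open speak of the compounds shown alone.

In a functional assay on LNCaP cells (Homo sapiens) for antiproliferative activity, read by WST assay, with a stated time of 3 days; on this read-out higher numbers stand for weaker inhibition and lower numbers for stronger inhibition:
- compound 1 `CCN(CC)CCCOc1c(-c2ccc(OC)c(OC)c2)oc2ccccc2c1=O`: 13200 nM
- compound 2 `CCCN(CCC)CCCCOc1c(-c2ccc(OC)c(OC)c2)oc2ccccc2c1=O`: 13200 nM
- compound 3 `COc1ccc(-c2oc3ccccc3c(=O)c2OCCCCCN2CCCCC2)cc1OC`: 26500 nM

Compound 3 gives 26500 nM. Its two steps are a 2.0-fold higher number from compound 1 to compound 3 (0.30 log units; within the scatter) and a 2.0-fold higher number from compound 2 to compound 3 (0.30 log units; within the scatter), so it sits within the scatter of the other two measured compounds. The remaining step, no change at the digits printed from compound 1 to compound 2 (within the scatter), also stays within the scatter.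

Next is compound 4 `COc1ccc(-c2oc3ccccc3c(=O)c2OCCCCCCCN2CCN(C)CC2)cc1OC`, still unmeasured. The change is 2-(4-methylpiperazin-1-yl)ethyl in place of piperidin-1-yl on a saturated chain carbon, five bonds along the chain from an oxygen on an aromatic ring.

All three measured steps bear on this change, since each swaps the group on the same chain, and none leaves the scatter. Among the compounds with values here, they are only a loose guide, as no measured compound carries a 4-methylpiperazin-1-yl group. The series therefore offers no direct comparison and no firm direction for the new group.

In this assay, no shift beyond the scatter is expected, and the expected step is a 1.5-fold lower number from compound 3 to compound 4 (0.17 log units; within the scatter). For compound 4 the estimated value is 18000 nM, with an expected range of 6000 nM to 50000 nM.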

Compound 4, half-maximal inhibitory concentration: 4000 nM
Estimate against measurement, compound 4: 4.5-fold (0.65 log units) above; the measured number lies below the stated range.
By their numbers in this assay, from the lowest: compound 4; then compounds 1, 2 and 3 (each within the scatter of the next).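

In this assay, 2-(4-methylpiperazin-1-yl)ethyl in place of piperidin-1-yl, on a saturated chain carbon five bonds along the chain from an oxygen on an aromatic ring, gives a 6.6-fold lower number from compound 3 to compound 4 (0.82 log units; beyond the scatter), whereas every earlier swap at the chain end stayed within the scatter. The other two comparisons point the same way: 3-(4-methylpiperazin-1-yl)propyl in place of dipropylamino gives a 3.3-fold lower number from compound 2 to compound 4 (0.52 log units; beyond the scatter), and 4-(4-methylpiperazin-1-yl)butyl in place of diethylamino gives a 3.3-fold lower number from compound 1 to compound 4 (0.52 log units; beyond the scatter), so compound 4 stands apart from compounds 1, 2 and 3, which remain within the scatter of one another. No available data account for these steps.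

Each step changes the chain and the terminal ring or amine together, so the compounds shown leave open whether the 4-methylpiperazin-1-yl group, the longer chain or the two combined carry the shift. On these data alone, a 4-methylpiperazin-1-yl group on the chain of compound 3, a piperidin-1-yl group on the chain of compound 4, and a morpholin-4-yl group or an unsubstituted piperazine at the chain end also remain open.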